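This account rests on a few compounds, and the source may have more. Where it says the series, first, only, none or still open, it means among the compounds named here.

Measured so far in a functional assay on HT-29 cells (Homo sapiens) for cytotoxicity, read by MTT assay, with a stated time of 72 h; on this read-out lower numbers stand for stronger inhibition and higher numbers for weaker inhibition:
compound 1 `COc1cc(C(=O)c2cc(OC)c(OC)c(OC)c2)cc(NC(=O)/C=C/c2cc(OC)c(OC)c(OC)c2)c1OC` gives 3100 nM
compound 2 `COc1cc(C(=O)c2cc(OC)c(OC)c(OC)c2)cc(NC(=O)/C=C/c2ccc(F)cc2)c1OC` gives 1800 nM
compound 3 `COc1cc(C(=O)c2cc(OC)c(OC)c(OC)c2)cc(NC(=O)/C=C/c2ccc(C(F)(F)F)cc2)c1OC` gives 1900 nM

Compound 3 holds the second highest of the three numbers in this assay. Its nearest neighbour is compound 2, with a 1.1-fold higher number from compound 2 to compound 3 (0.02 log units; within the scatter), and its furthest is compound 1, with a 1.6-fold lower number from compound 1 to compound 3 (0.21 log units; within the scatter). Among the compounds with values here, both steps lie within the scatter, so these three numbers give no order among the compounds.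

The next compound, compound 4 `COc1cc(C(=O)c2cc(OC)c(OC)c(OC)c2)cc(NC(=O)/C=C/c2cc(F)c(F)c(F)c2)c1OC`, differs from compound 3 in one place: 3,4,5-trifluorophenyl in place of 4-(trifluoromethyl)phenyl on a double-bonded chain carbon bound to a double-bonded chain carbon. Within the data shown here, two measured steps bear on this change, since each alters the same group on the same double-bonded chain carbon: a 1.6-fold lower number from compound 1 to compound 3 (0.21 log units; within the scatter) and a 1.1-fold higher number from compound 2 to compound 3 (0.02 log units; within the scatter). Neither exceeded the scatter, although one exchanges 3,4,5-trimethoxyphenyl for 4-(trifluoromethyl)phenyl and the other fluoro for trifluoromethyl. Placing 3,4,5-trifluorophenyl there instead is therefore expected to leave the number in this assay unchanged beyond the scatter, in neither direction. For compound 4 the expected step is no change at the digits printed from compound 3 to compound 4 (within the scatter). Compound 4 is thus estimated at 1900 nM in this assay, with a range from 900 nM to 4000 nM.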

Compound 4, half-maximal inhibitory concentration: 3300 nM
For compound 4 the middle estimate is 1.7-fold (0.24 log units) below the measured one; the measured number falls inside the stated range.
By their numbers in this assay, from the lowest: compounds 2, 3, 1 and 4 (each within the scatter of the next).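

Working in this assay, 3,4,5-trifluorophenyl on the double-bonded chain carbon extends the comparison to a fourth aryl group, and each of its steps stays within the scatter: a 1.7-fold higher number from compound 3 to compound 4 (0.24 log units; within the scatter) against 4-(trifluoromethyl)phenyl, a 1.8-fold higher number from compound 2 to compound 4 (0.26 log units; within the scatter) against 4-fluorophenyl, and a 1.1-fold higher number from compound 1 to compound 4 (0.03 log units; within the scatter) against 3,4,5-trimethoxyphenyl as the group replaced. Across compounds 1, 2, 3 and 4, this position has so far tolerated methoxy, fluoro and trifluoromethyl on the phenyl ring without any step beyond the scatter, so the series gives no order among these groups. No supporting measurement bears on this result.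

Every group shown at this position is a phenyl ring carrying methoxy, fluoro or trifluoromethyl, so it remains open whether an amine or a carboxylic acid on that ring would move the number beyond the scatter. Also open, as far as these compounds go, is whether a longer chain in place of the phenyl ring would do so, and whether the flat response seen with these four compounds would hold with any change to the shared core.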